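Swapping Fluoro for Methyl on Two Related Biaryl Cores

The source may report more compounds than this note shows. Statements on the series, on what has been measured and on what is new or still open speak of the compounds shown alone.

Of the compounds shown here, three have been tested in a functional assay on J774 cells (Mus musculus) for cytotoxicity, read by resazurin assay; a higher number here means a weaker inhibitor, a lower number a stronger inhibitor. Compound 1 `OCCCCCC(O)c1ccc(-c2ccc(F)cc2)cc1` gives 18000 nM, and compound 2 `Cc1ccc(-c2ccc(C(O)CCCCCO)cc2)cc1` gives 22000 nM. Compound 2 differs from compound 1 by methyl in place of fluoro on an aromatic carbon. The step of a 1.2-fold higher number from compound 1 to compound 2 (0.09 log units; within the scatter), so these two compounds cannot be told apart in this assay. Compound 3 `O=C(CCCCCO)c1ccc(-c2ccc(F)cc2F)cc1` gives 6000 nM, the lowest of the three numbers and beyond the scatter from both others. The difference between the core of compound 3 and the core of compound 1 is not broken down here.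

Compound 4 `Cc1cc(F)ccc1-c1ccc(C(=O)CCCCCO)cc1` has not yet been measured. It differs from compound 3 by methyl in place of fluoro on an aromatic carbon. Among the compounds with values here, this is the same kind of change as the one between compound 1 and compound 2, but the place is not the same: in compound 2 the methyl sits para to a large group, whereas in compound 4 it sits ortho to a large group and meta to a fluoro group. Because a 1.2-fold higher number from compound 1 to compound 2 (0.09 log units; within the scatter), a similarly small step a 1.2-fold higher number from compound 3 to compound 4 (0.07 log units; within the scatter) is expected here. Compound 4 is therefore expected to give about 7000 nM in this assay, most likely between 3500 nM and 14000 nM.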

Compound 4, half-maximal inhibitory concentration: 20000 nM
Compound 4: the middle estimate sits 2.9-fold (0.46 log units) below what was measured; measured number outside the range, above it.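

In this assay, putting methyl in place of fluoro gives a 3.3-fold higher number from compound 3 to compound 4 (0.52 log units; beyond the scatter), so on this core the swap leaves a clear mark on the number. The same swap therefore does not carry over from one core to the other with the same size: the same change on two cores in this assay, a 1.2-fold higher number (0.09 log units; within the scatter) from compound 1 to compound 2 and a 3.3-fold higher number (0.52 log units; beyond the scatter) from compound 3 to compound 4, 2.7-fold (0.44 log units) apart, beyond the scatter of two such steps What this does not show is the reason for the gap, as the swap sits in a different place in the two pairs and the cores differ as well, and two steps cannot pull those factors apart; nor do two steps make a rule for the series.

Still open, as far as these compounds go, is whether the larger step belongs to the place of the swap, ortho to a large group, or to the rest of the core of compound 3, such as its carbonyl. Also open, from the compounds shown here alone, is how a chloro or a methoxy group in that same place would compare with fluoro and methyl on either core.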